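From 4-methylpiperazin-1-yl to piperidin-1-yl at the assay limit

The source may report more compounds than this note shows. Statements on the series, on what has been measured and on what is new or still open speak of the compounds shown alone.

Compound 1 (`CCCCCCCCCCCCCCCCOP(=O)(O)OCCSC(=S)N1CCN(C)CC1`) was tested in an ADME assay on HEK293 cells (Homo sapiens) for inhibition, read by MTT assay, with stated times of 18 h and 4 h (a lower number here means a stronger inhibitor, a higher number a weaker inhibitor), and gives > 100000 nM as its result, which is a limit and not a number. Compound 2 (`CCCCCCCCCCOP(=O)(O)OCCSC(=S)N1CCN(C)CC1`), which differs only in its chain, gives > 100000 nM as its result, again a limit. Compound 3 (`CCCCCCCCOP(=O)(O)OCCSC(=S)N1CCN(C)CC1`), also differing only in its chain, gives 86000 nM as a true measured number. Compound 1 therefore has no exact place on the scale of this assay and is known only through its limit.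

Compound 4 (`CCCCCCCCCCCCCCCCOP(=O)(O)OCCSC(=S)N1CCCCC1`) keeps the chain and the shared core of compound 1 and changes one group: piperidin-1-yl in place of 4-methylpiperazin-1-yl on a thiocarbonyl carbon with piperidin-1-yl now on the thiocarbonyl carbon. The measured steps all alter the chain, so none tests this change directly. The two readable ones, an at least 1.1-fold lower number from compound 1 to compound 3 (0.06 log units; that floor lies within the scatter) and an at least 1.1-fold lower number from compound 2 to compound 3 (0.06 log units; that floor lies within the scatter) are only floors within the scatter, while a step that the two limits leave unreadable from compound 1 to compound 2 has no readable size. Because of the limit of > 100000 nM in this assay, at which 2 of the 3 values shown sit, these steps offer only a weak guide.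

The expected outcome is a number no higher from compound 1 to compound 4 (the limit leaves the size open) with no step beyond the scatter anticipated in either direction. The estimated value for compound 4 is 100000 nM with an expected range from 40000 nM to 200000 nM and another limit is quite possible.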

Compound 4, half-maximal inhibitory concentration: > 100000 nM
Compound 4: only a limit was reported (the forecaster's own chance of this, stated with the estimate: 60%); the middle value lies on the limit itself.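

Compound 4, like compound 1, is reported in this assay only as a limit and not as a number, so the change from 4-methylpiperazin-1-yl to piperidin-1-yl between these two compounds cannot be read as a step: the limit of > 100000 nM in this assay, at which 3 of the 4 values shown sit. The compounds shown leave open where compound 1 and compound 4 truly lie, and whether this change alters the result at all.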